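Trimming the Sulfonyl Chain Down to Methyl

The source may report more compounds than this note shows. Statements on the series, on what has been measured and on what is new or still open speak of the compounds shown alone.

Going by the values given here, in a physicochemical assay for lipophilicity (on this read-out lower numbers stand for lower lipophilicity and higher numbers for higher lipophilicity), compound 2 (`CCCCCCS(=O)(=O)c1ccc(O)c(C(=O)Nc2ccc(C(F)(F)F)cc2)c1`) gives 5.22 and stands lowest of the two numbers so far, under compound 1 (`CCCCCCCCCCCCS(=O)(=O)c1ccc(O)c(C(=O)Nc2ccc(C(F)(F)F)cc2)c1`) at 8.46 on the same scale. Compound 3 (`CS(=O)(=O)c1ccc(O)c(C(=O)Nc2ccc(C(F)(F)F)cc2)c1`) alters only the chain on the sulfonyl sulfur (hydrogen in place of pentyl on a saturated chain carbon bound to a sulfonyl sulfur), so that hexyl becomes methyl. Among the compounds with values here, the one measured step that bears on this is large and beyond the scatter (a number 3.24 log units lower from compound 1 to compound 2 (beyond the scatter)), and it trimmed the same chain, removing hexyl where this change removes pentyl. A single step is thin evidence, and the data do not show whether the drop stays even along the chain. A somewhat smaller drop in this assay is therefore expected, still beyond the scatter. The estimate is a number 2.62 log units lower from compound 2 to compound 3 (beyond the scatter) for this change. For compound 3 the estimated value is 2.6 (expected range 2 to 3.2).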

Compound 3, partition coefficient: 2.52
Compound 3: middle estimate off by 0.08 log units, on the high side; the range from low to high includes it.
By their numbers in this assay, from the lowest: compound 3; then compound 2; then compound 1.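

In this assay, shortening the chain on the sulfonyl sulfur keeps lowering the number right down to methyl, with a number 2.70 log units lower from compound 2 to compound 3 (beyond the scatter), and the full trim of the chain gives a number 5.94 log units lower from compound 1 to compound 3 (beyond the scatter). Removing pentyl gives a smaller step than removing hexyl did, yet when each step is divided by the carbons taken away, the two come out equal. Among these three compounds, then, the number falls evenly with each carbon lost, and none of them goes against this.

No measurement here explains this even fall. From the compounds shown here alone, it also remains open whether a branched chain, or a chain ending in an amine or a carboxylic acid, would fit the same pattern.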